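The source may hold more compounds than are shown below. What is called first, only, known or untested is meant among the compounds shown, and "the series" means these compounds.

In an ADME assay on Raji cells (Homo sapiens) for cytotoxicity, read by CellTiter-Glo and resazurin assay, with a stated time of 72 h (on this read-out higher numbers stand for an effect only at larger amounts of compound and lower numbers for an effect already at smaller amounts), compound 1 `CC(C)N(Cc1cccc(OCCCCCC(=O)O)c1)C(=O)c1ccc(-c2cccc3ccccc23)cc1` gives > 26000 nM, and this is a limit rather than a number. Compound 2 `CCOC(=O)CCCCCOc1cccc(CN(C(=O)c2ccc(-c3cccc4ccccc34)cc2)C(C)C)c1` gives > 26000 nM in this assay, which is also a limit. Compound 2 therefore has no exact position on the scale, and the picture so far is the limit of > 26000 nM in this assay, at which 2 of the 2 values shown sit.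

Compound 3 `CCOC(=O)CCCCCOc1cccc(CN(C(=O)c2ccc(-c3cccnc3)cc2)C(C)C)c1` keeps most of compound 2 but carries pyridin-3-yl in place of naphthalen-1-yl on an aromatic carbon, para to a large group: pyridin-3-yl in place of naphthalen-1-yl on an aromatic carbon. Among the measured compounds shown here, the only measured step is a step that the two limits leave unreadable from compound 1 to compound 2. It involves a different change, and it has no readable size to carry over. For the measured compounds named here, no measured pair tests a change at this aromatic carbon, so the forecast is a cautious one. The best guide is the limit of > 26000 nM in this assay, at which 2 of the 2 values shown sit, which suggests that compound 3 will most likely also be reported as a limit.

No step beyond the usual scatter is expected, and the estimated step is a step that the limit leaves unreadable from compound 2 to compound 3. For compound 3, the expected value is 30000 nM, with an estimated range from 12000 nM to 60000 nM.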

Compound 3, half-maximal effective concentration: > 26000 nM
Compound 3: a limit, no number; the forecaster's own chance of this, stated with the estimate: 85%; the middle value is on the limit's open side.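

In this assay compound 3 gives > 26000 nM, which is a limit rather than a number. Compound 2 also has only a limit, so no step can be read between compound 2 and compound 3. The compounds shown leave open where any of them would reach a half-maximal effect, and whether pyridin-3-yl in place of naphthalen-1-yl changes it.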